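The source may report more compounds than this note shows. Statements on the series, on what has been measured and on what is new or still open speak of the compounds shown alone.

Compound 1 `CCOc1ccc(NC2=CC(=O)c3c(nc4n3[C@H]3OC[C@@H](O)[C@H]3OC4)C2=O)cc1` carries a 4-ethoxyphenyl amine on the shared core. In a functional assay on ECa-109 cells for inhibition, with ECa-109 cell line (Homo sapiens) as the target, read by sulforhodamine B assay (on this read-out lower numbers stand for stronger inhibition and higher numbers for weaker inhibition), compound 1 reaches only a limit of the assay, > 4000 nM, and no number. Compound 2 `CCCc1ccc(NC2=CC(=O)c3nc4n(c3C2=O)[C@H]2OC[C@@H](O)[C@H]2OC4)cc1` likewise stops at a limit in this assay, > 4000 nM. Compound 3 `O=C1C=C(N2CCCCC2)C(=O)c2c1nc1n2[C@H]2OC[C@@H](O)[C@H]2OC1` also gives only a limit in this assay, > 8000 nM. Compound 1 thus sits at the limit of > 4000 nM in this assay, at which 2 of the 3 values shown sit, while compound 3 sits at the limit of > 8000 nM in this assay, at which 1 of the 3 values shown sits. Every value shown is a limit. Going by the values given here, no step between any two measured compounds can be counted, and no order among them can be stated.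

Compound 4 `O=C1C(Nc2ccc(I)cc2)=CC(=O)c2c1nc1n2[C@H]2OC[C@@H](O)[C@H]2OC1` differs from compound 1 in one place: iodo in place of ethoxy on an aromatic carbon. Among the compounds with values here, none of the measured compounds shows that any group on that ring brings the read-out inside the measurable range, so the step from compound 1 to compound 4 in this assay is expected to be none beyond the scatter: a step that the limit leaves unreadable from compound 1 to compound 4. Compound 4 is therefore estimated at 6000 nM, within a range of 1500 nM to 25000 nM, and most probably it will again be reported only as a limit.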

Compound 4, half-maximal inhibitory concentration: 2530 nM
For compound 4 the middle estimate is 2.4-fold (0.38 log units) above the measured one; the range from low to high includes it.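

Of the compounds shown, only compound 4 gives a real number in this assay, so the change from 4-ethoxyphenyl to 4-iodophenyl shows that this position can bring the read-out inside the measurable range. The change gives an at least 1.5-fold lower number from compound 1 to compound 4 (0.19 log units; that floor lies within the scatter). Since compound 1 has only a limit, the true step may be larger, but the part that can be counted stays within the scatter, and a limit remains the most common result: the limit of > 4000 nM in this assay, at which 2 of the 4 values shown sit.

Going by these compounds alone, it remains open whether the number depends on iodo itself or on the loss of ethoxy, and the single iodo compound cannot separate the two. Chloro, bromo or an amine at this position would test this, as would plain hydrogen.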